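A few compounds are considered here, and "the series" means these few. Any claim that something is new, unique, unknown or untested is made for them only; others in the source may bear on it.

Measured compounds:
- compound 1, `C[C@@H](CO)Nc1ncc(Cl)c(-c2cc3n(c2)C(=O)N([C@H](CO)c2cccc(Cl)c2)C3)n1`: 81 nM
- compound 2, `CC(C)Nc1cc(-c2cc3n(c2)C(=O)N([C@H](CO)c2cccc(Cl)c2)C3)c(Cl)cn1`: "not active" (no number reported)
- compound 3, `Cn1nccc1Nc1nccc(N2CC[C@H](C(=O)N[C@H](CO)c3cccc(Cl)c3)C2)n1`: > 10000 nM

For the measured compounds named here, in a functional assay on COLO 205 cells (Homo sapiens) for antiproliferative activity, read by luminescence, with a stated time of 72 h (on this read-out higher numbers stand for weaker inhibition and lower numbers for stronger inhibition), compound 1 gives the only numerical value of the set. Compound 2 is reported without a number in this assay. For compound 3 the figure is a limit of this assay, (the limit of > 10000 nM in this assay, at which 1 of the 3 values shown sits), not a number. Compound 4, `Cn1nccc1Nc1ncc(Cl)c(-c2cc3n(c2)C(=O)N([C@H](CO)c2cccc(Cl)c2)C3)n1`, is not yet measured; it differs from compound 1 by 1-methyl-1H-pyrazol-5-yl in place of 1-(hydroxymethyl)ethyl on a nitrogen on an aromatic ring. No measured pair differs in one place, so the size of this step is not shown; the value of compound 3 belongs to a different core and does not read on it. The expected step from compound 1 to compound 4 is a 2.0-fold lower number from compound 1 to compound 4 (0.31 log units; beyond the scatter), a modest gain not clearly beyond the scatter. Compound 4 is estimated at 40 nM, within 8 nM to 300 nM.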

Compound 4, half-maximal inhibitory concentration: 31.9 nM
Estimate against measurement, compound 4: 1.3-fold (0.10 log units) above; the measured number falls inside the stated range.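

In this assay, for the compounds shown here, 1-methyl-1H-pyrazol-5-yl in place of 1-(hydroxymethyl)ethyl on a nitrogen on an aromatic ring gives a 2.5-fold lower number from compound 1 to compound 4 (0.40 log units; beyond the scatter) and this is the only readable step. It shows that this position accepts an aromatic ring in place of an open chain without loss of antiproliferative activity. Nothing at hand bears on what lies behind the step. Open, on these data alone, is how a plain amine, a longer chain or a carboxylic acid at this position would read, and whether a six-membered aromatic ring would hold the number.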